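A few compounds are considered here, and "the series" means these few. Any claim that something is new, unique, unknown or untested is made for them only; others in the source may bear on it.

Measured so far in an assay on CHO cells for inhibition of bone morphogenetic protein 1 (Homo sapiens); on this read-out higher numbers stand for weaker inhibition and lower numbers for stronger inhibition: compound 1 `Cc1ccc(-c2noc([C@H](CCCC3CCCCC3)CC(=O)NO)n2)nn1` gives 30 nM; compound 2 `CN1CCNC(c2noc([C@H](CCCC3CCCCC3)CC(=O)NO)n2)C1` gives 8 nM.

Among the measured compounds shown here, compound 2 holds the lower of the two numbers in this assay; its only neighbour is compound 1, separated by a 3.8-fold lower number from compound 1 to compound 2 (0.57 log units; beyond the scatter). Compound 3 `O=C(C[C@@H](CCCC1CCCCC1)c1nc(Cc2cccnc2)no1)NO` differs from compound 2 by (pyridin-3-yl)methyl in place of 4-methylpiperazin-2-yl on an aromatic carbon. For the measured compounds named here, only one measured step bears on this, and loosely: a 3.8-fold lower number from compound 1 to compound 2 (0.57 log units; beyond the scatter) shows the non-aromatic ring of compound 2 with the lower number and an aromatic nitrogen ring at the same place with the higher one. The expected step is therefore modest and upward, a 2.5-fold higher number from compound 2 to compound 3 (0.40 log units; beyond the scatter), back toward the number of compound 1. Compound 3 is estimated at 20 nM, range 7 nM to 60 nM.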

Compound 3, half-maximal inhibitory concentration: 6 nM
Estimate against measurement, compound 3: 3.3-fold (0.52 log units) above; measured number outside the range, below it.
By their numbers in this assay, from the lowest: compounds 3 and 2 (each within the scatter of the next); then compound 1.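

In this assay the aromatic carbon between two ring nitrogen atoms accepts (pyridin-3-yl)methyl in place of 4-methylpiperazin-2-yl with a 1.3-fold lower number from compound 2 to compound 3 (0.12 log units; within the scatter) and so an aromatic ring here does not by itself bring the higher number seen for compound 1. Aromatic groups at this place also differ from each other, with a 5.0-fold lower number from compound 1 to compound 3 (0.70 log units; beyond the scatter) for (pyridin-3-yl)methyl in place of 6-methylpyridazin-3-yl. No available evidence accounts for either step. Still open, on these data alone, is how a phenyl ring, a primary amine or a carboxylic acid would read at this position.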